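The source may hold more compounds than are shown below. What is called first, only, known or untested is meant among the compounds shown, and "the series" means these compounds.

The measured compounds:

compound 1 `COc1ccc(/C=C/C(=O)NCCCC(C)Nc2cc(OC)cc3cccnc23)cc1` — > 240000 nM
compound 2 `COc1cc(NC(C)CCCNC(=O)/C=C/c2ccc(OC)c(OC)c2)c2ncccc2c1` — > 220000 nM
compound 3 `COc1cc(NC(C)CCCNC(=O)NNC(=O)/C(C)=C/c2ccccc2)c2ncccc2c1` — 36500 nM

In an ADME assay on L6 cells (Rattus norvegicus) for cytotoxicity, read by resazurin assay, with a stated time of 70 h (a lower number here means a stronger inhibitor, a higher number a weaker inhibitor), compound 1 gives only a limit, > 240000 nM. Compound 2 likewise gives only a limit, > 220000 nM. Compound 3 gives 36500 nM, the only number among the three shown. Among the compounds with values here, the single step between measured compounds that differ in one place, a step that the two limits leave unreadable from compound 1 to compound 2, joins two limits and its size cannot be read, as the limit of > 220000 nM in this assay, at which 1 of the 3 values shown sits, and the limit of > 240000 nM in this assay, at which 1 of the 3 values shown sits, show.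

Compound 4 `COc1cc(NC(C)CCCNC(=O)NNC(=O)/C=C/c2ccc(OC)c(OC)c2)c2ncccc2c1` is not yet measured in this assay; it differs from compound 3 by 2-(3,4-dimethoxyphenyl)ethenyl in place of 1-methyl-2-phenylethenyl on a carbonyl carbon. Within the data shown here, no measured step bears on this change directly. Among the measured compounds shown here, the side chain that enters is the one carried by compound 2, and compound 2 gives only a limit in this assay. Compound 4 is therefore expected to sit toward the weak end, with an estimated value of 90000 nM, between 25000 nM and 300000 nM. The expected step of a 2.5-fold higher number from compound 3 to compound 4 (0.39 log units; beyond the scatter) points toward weaker inhibition, with a real chance that only a limit is reported.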

Compound 4, half-maximal inhibitory concentration: 37000 nM
For compound 4 the middle estimate is 2.4-fold (0.39 log units) above the measured one; the measured number falls inside the stated range.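

In this assay, 2-(3,4-dimethoxyphenyl)ethenyl in place of 1-methyl-2-phenylethenyl on a carbonyl carbon gives a 1.0-fold higher number from compound 3 to compound 4 (0.01 log units; within the scatter), so this change does not separate the two groups at this position. Compound 2 carries the same 2-(3,4-dimethoxyphenyl)ethenyl and gives only the limit > 220000 nM there. Compound 4 shows that this group does not by itself bring a compound to such a limit, and nothing shown gives a cause for the result.

From the compounds shown here alone, the change swaps the methyl and the two methoxy groups at once, so what each contributes alone stays open. Also open, going by these compounds, is whether an amine or a carboxylic acid on the phenyl ring, or a longer chain in place of the ethenyl, would move the number.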